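A few compounds are considered here, and "the series" means these few. Any claim that something is new, unique, unknown or untested is made for them only; others in the source may bear on it.

Working notes on the series. In an ADME assay on HEK-293T cells (Homo sapiens) for cytotoxicity, read by CCK-8 assay, with a stated time of 48 h (on this read-out lower numbers stand for stronger inhibition and higher numbers for weaker inhibition), compound 1 `Cc1cc(C)cc(NC(=O)NCCNS(=O)(=O)c2ccc(-c3ccccc3Oc3ccc([N+](=O)[O-])c([N+](=O)[O-])c3)s2)c1` gives > 50000 nM, which is a limit and not a number. Compound 2 `O=C(NCCNS(=O)(=O)c1ccc(-c2ccccc2Oc2ccc([N+](=O)[O-])c([N+](=O)[O-])c2)s1)Nc1cc(Cl)cc(Cl)c1` gives > 20000 nM, also a limit. Compound 3 `O=C(NCCNS(=O)(=O)c1ccc(-c2ccccc2Oc2ccc([N+](=O)[O-])c([N+](=O)[O-])c2)s1)Nc1ccc([N+](=O)[O-])cc1` gives a true number, 16600 nM. Compound 1 therefore has no exact standing, and only compound 3 has a measured number.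

Compound 4 `Cc1cc(C)cc(NC(=O)NCCNS(=O)(=O)c2ccc(-c3ccccc3OCc3ccccc3)s2)c1` takes benzyl in place of 3,4-dinitrophenyl on an oxygen on an aromatic ring. The 3,5-dimethylphenyl on the amide-type nitrogen of compound 1 stays.

The measured steps all lie at that amide-type nitrogen, and none touches the oxygen substituent. They are a step that the two limits leave unreadable from compound 1 to compound 2, an at least 3.0-fold lower number from compound 1 to compound 3 (0.47 log units; beyond the scatter) and an at least 1.2-fold lower number from compound 2 to compound 3 (0.08 log units; that floor lies within the scatter). They bear on the new change only indirectly, showing that this assay can move within this series. Among the compounds with values here, no measured step gives a direction for the swap at the oxygen.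

The expectation therefore starts from compound 1 and its limit of > 50000 nM, with no shift beyond the scatter expected. The expected outcome is a number no higher from compound 1 to compound 4 (the limit leaves the size open), and another report of only a limit is quite possible. Compound 4 is estimated at 50000 nM, with an expected range of 20000 nM to 100000 nM.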

Compound 4, half-maximal inhibitory concentration: > 20000 nM
Compound 4: only a limit was reported; the forecaster's own chance of this, stated with the estimate: 60%; the middle value lies beyond the limit too.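

In this assay compound 4 gives > 20000 nM, a limit and not a number. Within the data shown here, compound 1 also stands only at a limit, so no step from compound 1 to compound 4 can be read. The compounds shown leave open whether benzyl in place of 3,4-dinitrophenyl on the oxygen shifts this read-out at all, and in which direction.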